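The compounds below may be only part of what the source reports. "The series", "measured", "known", "first", "only" and "open" are said of these compounds alone.

Measured so far in an assay on membranes from HEK293 cells for displacement of a labelled ligand from adenosine receptor A2b (Homo sapiens), read by scintillation counting, with a stated time of 30 min, tested at 1 uM; on this read-out lower numbers stand for less inhibition and higher numbers for more inhibition at the one concentration tested (going by the name of the read-out):
- compound 1 `COC(=O)C1=C(C)NC(=O)NC1c1cccs1`: 19%
- compound 2 `CCNC(=O)C1=C(C)NC(=O)NC1c1ccoc1`: 2%

Compound 2 stands lowest of the two numbers in this assay. Its nearest neighbour is compound 1, whose inhibition is higher by a margin beyond the usual scatter, though the two compounds differ both in the group on the ring carbon and in the ester versus ethylcarbamoyl substituent, so no single-point step can be read from them.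

Compound 3 `CCNC(=O)C1=C(C)NC(=O)NC1c1cccs1` has not yet been measured. It differs from compound 2 in one place: thiophen-2-yl in place of furan-3-yl on a saturated ring carbon. Going by the values given here, the group that enters is the one carried by compound 1, while the ethylcarbamoyl group of compound 2 is kept, so compound 3 sits between the two measured compounds structurally.

With no single-point step available, the expected step from compound 2 to compound 3 in this assay is a modest rise, a number 7 percentage points higher from compound 2 to compound 3 (within the scatter), resting only on the higher inhibition shown by compound 1 with the same thiophen-2-yl group. Compound 3 is estimated at 9%, within 0% to 22%.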

Compound 3, a percentage reported as inhibition, at one concentration (the size of the read-out at that concentration, not a potency): 1%
Compound 3: the middle estimate sits 8 percentage points above what was measured; the range from low to high includes it.
By their numbers in this assay, from the lowest: compounds 3 and 2 (each within the scatter of the next); then compound 1.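

In this assay, thiophen-2-yl in place of furan-3-yl on the saturated ring carbon, with the ethylcarbamoyl group kept, gives a number 1 percentage points lower from compound 2 to compound 3 (within the scatter) and so does not separate these two five-membered aromatic rings when the ethylamino group is present. Going by these compounds alone, with thiophen-2-yl held constant, ethylamino in place of methoxy on the carbonyl carbon gives a number 18 percentage points lower from compound 1 to compound 3 (beyond the scatter) and is the only single-place step beyond the scatter so far, which places the measurable change at the carbonyl carbon rather than the saturated ring carbon. Nothing available accounts for either step.

From the compounds shown here alone, compound 2 and compound 3 both lie close to the bottom of the read-out, so the ring comparison remains open with methoxy on the carbonyl carbon, where compound 1 gives 19% and a furan-3-yl partner would provide a direct test. Also open, going by these compounds, is how this assay responds to other groups on the carbonyl carbon, such as ethoxy or a plain amino group, and to a phenyl ring on the saturated ring carbon.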